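The source may hold more compounds than are shown below. What is called first, only, known or untested is meant among the compounds shown, and "the series" means these compounds.

Compound 2 `C=CC(=O)N1C(=O)CC(c2ccc(C)cc2)Sc2ccccc21` is one of three compounds with a shared core measured in a functional assay on Raji cells (Homo sapiens) for cytotoxicity, read by CCK-8 assay, with a stated time of 24 h; a lower number here means a stronger inhibitor, a higher number a weaker inhibitor. Compound 1 `C=CC(=O)N1C(=O)CC(c2ccc([N+](=O)[O-])cc2)Sc2ccccc21` gives 34800 nM in this assay, and compound 3 `C=CC(=O)N1C(=O)CC(c2cccc(Cl)c2)Sc2ccccc21` gives 47100 nM. Compound 2 gives 75500 nM, the highest of the three numbers; its nearest neighbour is compound 3, and compound 1 lies furthest from it. The change to compound 4 `C=CC(=O)N1C(=O)CC(c2ccc(C(=O)OC)cc2)Sc2ccccc21` is methoxycarbonyl in place of methyl on an aromatic carbon. Among the compounds with values here, only one measured step touches the same aromatic carbon: a 2.2-fold higher number from compound 1 to compound 2 (0.34 log units; beyond the scatter), where a group with two oxygens was removed. The step of a 1.6-fold lower number from compound 2 to compound 3 (0.20 log units; within the scatter) involves a different position and is within the scatter, so it says little here. Since compound 1 gives 34800 nM with an oxygen-bearing group at this carbon, and methoxycarbonyl also brings two hydrogen-bond acceptors, a modest lowering is expected. He therefore estimates a step of a 1.7-fold lower number from compound 2 to compound 4 (0.22 log units; within the scatter) for compound 4. Compound 4 is expected to give 45000 nM in this assay, within a range from 20000 nM to 100000 nM.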

Compound 4, half-maximal inhibitory concentration: 89600 nM
For compound 4 the middle estimate is 2.0-fold (0.30 log units) below the measured one; the measured number falls inside the stated range.
By their numbers in this assay, from the lowest: compounds 1, 3, 2 and 4 (each within the scatter of the next, the first and the last beyond it).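

In this assay, the exchange at this aromatic carbon gives a 1.2-fold higher number from compound 2 to compound 4 (0.07 log units; within the scatter), so methoxycarbonyl, with its two hydrogen-bond acceptors, cannot be told apart from methyl here. Set against nitro at the same carbon, the picture differs, with a 2.6-fold higher number from compound 1 to compound 4 (0.41 log units; beyond the scatter). Carrying oxygen at this carbon therefore does not by itself go with the lower number of compound 1, and no measurement at hand accounts for the gap between these two oxygen-bearing groups.

From the compounds shown here alone, whether an amine or a carboxylic acid at this carbon would fall with compound 1 or with compound 4 remains open. Every number shown also comes from this assay, so whether the gap between nitro and methoxycarbonyl would persist in other cells is unknown.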